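Adding an Isopropyl Branch Beside the Ester of Compound 1

A few compounds are considered here, and "the series" means these few. Any claim that something is new, unique, unknown or untested is made for them only; others in the source may bear on it.

Measured compounds:
Compound 1, `O=C(CN(c1ncnc2c1ncn2C1CCCCO1)C1CC1)NCC(=O)OCc1ccccc1`, gives 7.26%.
Compound 2, `O=C(CN(c1nc(Cl)nc2[nH]cnc12)C1CC1)N[C@@H](CO)C(=O)O`, gives 18.8%.

Both numbers come from a functional assay on the whole organism (Tail, strain ICR) with Mus musculus as the target, in the tail flick test, with a stated time of 150 min, at a dose of 25 umol/kg by the oral route; a higher number here means a stronger effect of the compound at the dose given, a lower number a weaker effect. Of the two compounds tested, compound 1 stands lowest; compound 2 lies higher by a margin that is beyond the usual scatter of this kind of measurement. Compound 2 differs from compound 1 in several places at once, so nothing can be drawn from that gap about any single change.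

Compound 3, `CC(C)[C@H](NC(=O)CN(c1ncnc2c1ncn2C1CCCCO1)C1CC1)C(=O)OCc1ccccc1`, is built from compound 1 by one change: isopropyl in place of hydrogen on a saturated chain carbon bound to an amide-type nitrogen and a carbonyl carbon. Among the compounds with values here, no pair of measured compounds shows what this particular change does, so there is no measured step to lean on. The expected step from compound 1 to compound 3 in this assay is therefore small and without a clear direction, likely within the scatter. Compound 3 is estimated to give 10%, with a range from 0% to 25%, which means an expected step of a number 2.7 percentage points higher from compound 1 to compound 3 (within the scatter).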

Compound 3, a percentage reported as activity, at one dose (the size of the read-out at that dose, not a potency): 21.1%
The estimate for compound 3 lay 11.1 percentage points below the measured number; low and high end bracket the measured number.
By their numbers in this assay, from the lowest: compound 1; then compounds 2 and 3 (each within the scatter of the next).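

In this assay the change gives a number 13.8 percentage points higher from compound 1 to compound 3 (beyond the scatter) when isopropyl replaces hydrogen on the saturated chain carbon bound to an amide-type nitrogen and a carbonyl carbon. Within the data shown here, this is the first comparison here between compounds that differ in only one place, so the gap can be tied to this single change. It shows that this carbon can carry a branched group of 3 heavy atoms without losing the effect at the dose given, and that the read-out goes up with it. Nothing measured here bears on what lies behind this rise.

The compounds shown leave open whether a single methyl group or a longer chain such as butyl at this same carbon would also raise the number. They also leave open whether the same isopropyl would give a similar step on a different core.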